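The compounds below may be only part of what the source reports. "The series", "measured", "known", "first", "only" and "open" are said of these compounds alone.

In an ADME assay on MDBK cells (Bos taurus) for cytotoxicity (on this read-out lower numbers stand for higher toxicity in this test and higher numbers for lower toxicity in this test), compound 3 `CC(C)CCn1ccc2nc(-c3ccccc3)nc-2c1` gives > 100000 nM, which is a limit of the assay and not a number. Compound 1 `COc1cccc(Cn2ccc3nc(-c4ccccc4)nc-3c2)c1` gives > 100000 nM, which is also a limit. Compound 2 `Brc1ccccc1Cn1ccc2nc(-c3ccccc3)nc-2c1` gives > 100000 nM, again a limit. Going by these compounds, compound 3 therefore cannot be ranked against the other two, and its true value remains unknown.

Compound 4 `CC(C)N(CCn1ccc2nc(-c3ccccc3)nc-2c1)C(C)C` keeps the core of compound 3 and changes only the end of the side chain: diisopropylamino in place of isopropyl on a saturated chain carbon, two bonds along the chain from an aromatic nitrogen. In words, this is diisopropylamino in place of isopropyl on a saturated chain carbon, two bonds along the chain from an aromatic nitrogen.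

The closest measured comparisons are a step that the two limits leave unreadable from compound 1 to compound 3 and a step that the two limits leave unreadable from compound 2 to compound 3, and the remaining comparison is a step that the two limits leave unreadable from compound 1 to compound 2. None of them has a readable size, so they supply no number to carry over to the new change. What they do offer is a shared position, (the limit of > 100000 nM in this assay, at which 3 of the 3 values shown sit). Compounds 1, 2 and 3 carry quite different side groups, yet none gives a measured number in this assay. With so little to go on, only a modest move towards higher toxicity is expected, shown as an at least 1.6-fold lower number from compound 3 to compound 4 (0.22 log units; that floor lies within the scatter), and another limit would be no surprise. For compound 4 the estimated value is 60000 nM, with an expected range of 15000 nM to 100000 nM.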

Compound 4, half-maximal cytotoxic concentration: > 100000 nM
Compound 4: a limit, no number (the forecaster's own chance of this, stated with the estimate: 50%); at least 1.6-fold (0.22 log units) between middle value and limit.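

In this assay compound 4 gives > 100000 nM, which is a limit and not a number. No step linking compound 4 to compound 1, compound 2 or compound 3 can be read, because all four compounds stop at one limit: the limit of > 100000 nM in this assay, at which 4 of the 4 values shown sit. The compounds shown leave open what their true values are and whether any side chain on the shared core gives a measurable number.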